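Amide to Urea on the Shared Core

The source may hold more compounds than are shown below. What is called first, only, known or untested is meant among the compounds shown, and "the series" means these compounds.

Measured compounds:
compound 1, `O=C(Nc1cccc(-n2cc(-c3ccncc3)c(-c3ccc(Cl)c(O)c3)n2)c1)Nc1cccc(C(F)(F)F)c1` — 9820 nM
compound 2, `COc1cc(-c2nn(-c3cccc(NC(=O)Nc4cc(C(F)(F)F)cc(C(F)(F)F)c4)c3)cc2-c2ccncc2)ccc1Cl` — 702 nM
compound 3, `COc1cc(-c2nn(-c3cccc(NC(=O)c4cccc(C(F)(F)F)c4)c3)cc2-c2ccncc2)ccc1Cl` — 1390 nM

Of the compounds shown here, three have been tested in a functional assay on HT-29 cells (Homo sapiens) for inhibition, read by sulforhodamine B assay, with a stated time of 48 h; on this read-out higher numbers stand for weaker inhibition of growth and lower numbers for stronger inhibition of growth. Compound 1 gives 9820 nM, compound 2 gives 702 nM and compound 3 gives 1390 nM. Compound 3 thus stands second highest of the three numbers; its nearest neighbour is compound 2, whose value lies within the scatter of that of compound 3, while compound 1 stands well above both, beyond the scatter.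

Compound 4, `COc1cc(-c2nn(-c3cccc(NC(=O)Nc4ccc(Cl)c(Cl)c4)c3)cc2-c2ccncc2)ccc1Cl`, has not yet been measured. It differs from compound 3 in one place: (3,4-dichlorophenyl)amino in place of 3-(trifluoromethyl)phenyl on a carbonyl carbon. Compound 2 shows that a urea of this kind on the shared core with a methoxy-bearing aryl gives a number in the same range as the amide of compound 3. Going by the values given here, no measured pair isolates this exact change, so the size of the step is uncertain. The step of a 1.5-fold lower number from compound 3 to compound 4 (0.19 log units; within the scatter) is expected to be small, towards a lower number but not clearly beyond the scatter. For compound 4 the estimate in this assay is 900 nM, with a range from 300 nM to 3000 nM.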

Compound 4, concentration for 50% growth inhibition: 1240 nM
Estimate against measurement, compound 4: 1.4-fold (0.14 log units) below; the measured number falls inside the stated range.
By their numbers in this assay, from the lowest: compounds 2, 4 and 3 (each within the scatter of the next); then compound 1.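

In this assay, (3,4-dichlorophenyl)amino in place of 3-(trifluoromethyl)phenyl on a carbonyl carbon gives a 1.1-fold lower number from compound 3 to compound 4 (0.05 log units; within the scatter), the first step shown between compounds that differ in one place. At this place the read-out therefore does not separate the amide from this urea, although the entering group carries a hydrogen-bond donor that the leaving group lacks. Nothing at hand bears on why this result arises.

This single step exchanges the carbonyl-linked group and the substituents on its aromatic ring together, so their separate contributions remain unresolved. Going by these compounds, it also remains open how the read-out would respond to a carboxylic acid or a morpholine on that ring, or to a longer chain on the carbonyl carbon.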